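A few compounds are considered here, and "the series" means these few. Any claim that something is new, unique, unknown or untested is made for them only; others in the source may bear on it.

The measured compounds:

compound 1 `Cc1cc(Cl)cc(-c2ccnc3cc(CN4C(=O)C5C(C4=O)C5(C)C)sc23)c1C[C@@H]1CNCCO1` gives 0.44 nM
compound 2 `Cc1cc(Cl)cc(-c2ccnc3cc(CN4C(=O)CCC4=O)sc23)c1CN1CCNC[C@@H]1C` gives 6.6 nM
compound 3 `Cc1cc(Cl)cc(-c2ccnc3cc(CN4C(=O)C5C(C4=O)C5(C)C)sc23)c1CC1CCCNC1` gives 1.3 nM

All three were tested in an assay on isolated protein for inhibition of ubiquitin carboxyl-terminal hydrolase 7 (Homo sapiens), read by fluorescence, with stated times of 30 min and 1 h; on this read-out higher numbers stand for weaker inhibition and lower numbers for stronger inhibition. Compound 1 stands lowest of the three numbers. Its nearest neighbour is compound 3, reached by a 3.0-fold higher number from compound 1 to compound 3 (0.47 log units; beyond the scatter), a change that sits on the amine-bearing ring hanging from the shared core. Compound 2 is furthest away; it differs from compound 1 in two places at once, so its gap cannot be assigned to either change alone.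

Compound 4 `Cc1cc(Cl)cc(-c2ccnc3cc(CN4C(=O)C5CC5C4=O)sc23)c1C[C@@H]1CNCCO1` keeps everything from compound 1 except the imide portion: a group of 8 heavy atoms (5 carbon, 1 nitrogen, 2 oxygen; one three-membered non-aromatic ring of carbon only, one five-membered non-aromatic ring with 1 hetero atom) in place of a group of 10 heavy atoms (7 carbon, 1 nitrogen, 2 oxygen; one three-membered non-aromatic ring of carbon only, one five-membered non-aromatic ring with 1 hetero atom), on a saturated chain carbon bound to an aromatic carbon. In plain terms, the group that enters is a smaller version of the one that leaves, on the same saturated chain carbon bound to an aromatic carbon. Going by the values given here, no measured step changes this part of the molecule on its own. Among the compounds with values here, the single step that exists, from compound 1 to compound 3, concerns a different region and was modest in size, and compound 2 confounds two changes. The evidence for this step is therefore thin. A modest move towards a higher number is expected for compound 4, a 2.3-fold higher number from compound 1 to compound 4 (0.36 log units; beyond the scatter). The estimate for compound 4 in this assay is 1 nM, with a range from 0.35 nM to 3 nM.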

Compound 4, half-maximal inhibitory concentration: 0.16 nM
Compound 4: the middle estimate sits 6.3-fold (0.80 log units) above what was measured; measured number outside the range, below it.
By their numbers in this assay, from the lowest: compound 4; then compound 1; then compound 3; then compound 2.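

Going by these compounds alone, the imide portion, on a saturated chain carbon bound to an aromatic carbon, now has a readable step of its own, whereas the only earlier single-change step concerned the amine-bearing ring. In this assay, placing the group of 8 heavy atoms where the group of 10 heavy atoms stood gives a 2.8-fold lower number from compound 1 to compound 4 (0.44 log units; beyond the scatter), so the smaller of these two groups does not cost inhibition here and the number in fact improves. No measurement that could explain this gain accompanies the step, so the reason for it stays unknown.

As far as these compounds go, whether the smaller group would give a similar gain with the piperidin-3-yl of compound 3 in place of the morpholin-2-yl of compound 4 remains open, since one step at this position cannot show how far the effect carries over to other compounds. Also open, from the compounds shown here alone, is whether a single methyl group on the three-membered ring would give a number closer to that of compound 1 or compound 4, and how ethyl groups on that ring would compare.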